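This account rests on a few compounds, and the source may have more. Where it says the series, first, only, none or still open, it means among the compounds named here.

Compound 1 `Cc1occc1-c1nn2c(-c3ccncc3)nnc2s1`: 58.4%
Compound 2 `Fc1ccc(OCc2nn3c(-c4ccncc4)nnc3s2)cc1`: 32%

In a functional assay on NCI-H157 cells (Homo sapiens) for antiproliferative activity, read by sulforhodamine B assay, with a stated time of 48 h, tested at 100 uM (on this read-out lower numbers stand for less inhibition of growth and higher numbers for more inhibition of growth at the one concentration tested), compound 2 gives 32%, the lower of the two numbers, and the gap to compound 1 at 58.4% lies beyond the scatter. Compound 3 `COc1ccc(OCc2nn3c(-c4ccncc4)nnc3s2)cc1` has methoxy in place of fluoro on an aromatic carbon, para to a large group: methoxy in place of fluoro on an aromatic carbon. Among the compounds with values here, no measured pair shows this change, and the two compounds in hand differ in more than one place. The estimated step of a number 3 percentage points higher from compound 2 to compound 3 (within the scatter) in this assay is therefore small, and none beyond the scatter is expected. For compound 3 the expected value is 35%, with an estimated range from 20% to 52%.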

Compound 3, percent growth inhibition at one concentration: 68.9%
Estimate against measurement, compound 3: 33.9 percentage points below; measured number above the stated range.
By their numbers in this assay, from the lowest: compound 2; then compound 1; then compound 3.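

Methoxy in place of fluoro on an aromatic carbon, para to a large group, gives a number 36.9 percentage points higher from compound 2 to compound 3 (beyond the scatter) in this assay. Growth inhibition at the one concentration tested therefore depends strongly on the group at this place, which the first two compounds, differing in more than one place, could not show. Nothing available bears on why this change has such an effect. The compounds shown leave open whether an amine, a carboxylic acid or a longer alkoxy chain at this place would keep or lose the higher number.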